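Swapping the Phenyl for Butyl on the Chain

The source may hold more compounds than are shown below. What is called first, only, known or untested is meant among the compounds shown, and "the series" means these compounds.

The starting point is compound 1 `c1ccc(CCc2cccc(N3CCNCC3)n2)cc1`, tested in a functional assay on the whole organism with Mus musculus as the target, in the maximal electroshock model, with a stated time of 120 min; on this read-out lower numbers stand for an effect already at smaller amounts and higher numbers for an effect only at larger amounts of compound. In this assay compound 1 reaches only the limit of > 300 mg/kg, which is a boundary of the test and not a measured number, so its true position is known only as lying at the limit of > 300 mg/kg in this assay, at which 1 of the 3 values shown sits. Two other measured compounds give a sense of the scale: compound 2 `CCCCCCCc1cccc(N2CCN(C)CC2)n1` gives 30 mg/kg in this assay, and compound 3 `CCCCCCCc1ccnc(N2CCNCC2)c1` gives 30 mg/kg; these two sit within the scatter of each other, so no order between them can be claimed.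

The unmeasured compound 4 `CCCCCCc1cccc(N2CCNCC2)n1` differs from compound 1 by butyl in place of phenyl on a saturated chain carbon, two bonds along the chain from an aromatic carbon. Compounds 2 and 3 both carry a saturated chain on the aromatic core, and both give a number in this assay where compound 1 gives only a limit. On that basis compound 4 is expected to move in the direction of smaller doses, a step of about an at least 10-fold lower number from compound 1 to compound 4 (1.00 log units; beyond the scatter). Compound 4 is therefore estimated at 30 mg/kg, with a likely range from 10 mg/kg to 100 mg/kg.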

Compound 4, minimum effective dose: 10 mg/kg
Beside the measured number, compound 4's estimate is 3.0-fold (0.48 log units) above it, and the stated range covers the measured number.
By their numbers in this assay, from the lowest: compound 4; then compounds 2 and 3 (each within the scatter of the next). At a limit, above all of these: compound 1.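

In this assay, compound 1 and compound 4 differ only at this chain carbon, and the change of phenyl to butyl gives an at least 30-fold lower number from compound 1 to compound 4 (1.47 log units; beyond the scatter). For the compounds shown here, this is the first direct comparison at this position, and it shows that an aromatic ring at the end of the chain is not needed for an effect in this test, since an open butyl group gives a measurable dose. The true step may be larger, since compound 1 stands at a limit of the test: the limit of > 300 mg/kg in this assay, at which 1 of the 4 values shown sits.

The compounds shown leave open whether the step follows from losing the aromatic ring or from the change in the group's size, and a cyclohexyl group at this place would separate the two. From the compounds shown here alone, how a longer chain or a chain ending in an amine would read here also remains open.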